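From ethoxycarbonyl to tert-butyl on a shared core

The compounds below may be only part of what the source reports. "The series", "measured", "known", "first", "only" and "open" are said of these compounds alone.

In a functional assay on HeLa cells (Homo sapiens) for inhibition, read by CCK-8 assay, with a stated time of 48 h (on this read-out lower numbers stand for stronger inhibition and higher numbers for weaker inhibition), compound 1 (`COc1cc(-c2ccnc3cc(-c4cccc(C#N)c4)nn23)cc(OC)c1OC`) gives > 10000 nM and that value is a limit. Compound 2 (`CCOC(=O)c1ccc(-c2cc3nccc(-c4cc(OC)c(OC)c(OC)c4)n3n2)cc1`) gives > 10000 nM in this assay and that value too is a limit, so no number places it. Compound 3 (`COc1cc(-c2ccnc3cc(-c4ccc(C(C)(C)C)cc4)nn23)cc(OC)c1OC`) carries tert-butyl in place of ethoxycarbonyl on an aromatic carbon, para to a large group (tert-butyl in place of ethoxycarbonyl on an aromatic carbon). Going by the values given here, no measured step speaks to this change, and the expectation for compound 2 rests only on the limit of > 10000 nM in this assay, at which 2 of the 2 values shown sit, as a reference. In this assay no change beyond the scatter is expected, the estimated move being a number no higher from compound 2 to compound 3 (the limit leaves the size open) in size. Compound 3 is estimated at 10000 nM (expected range 1500 nM to 30000 nM).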

Compound 3, half-maximal inhibitory concentration: > 10000 nM
Compound 3 ended at the assay's limit (the forecaster's own chance of this, stated with the estimate: 65%); the middle value lies on the limit itself.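

Going by these compounds alone, compound 1, compound 2 and compound 3 all stand at a limit in this assay, so no step among them can be read. The compounds shown leave open which group on the shared core, if any, would give a number rather than a limit: the limit of > 10000 nM in this assay, at which 3 of the 3 values shown sit.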